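The source may hold more compounds than are shown below. What is called first, only, known or untested is meant among the compounds shown, and "the series" means these compounds.

Measured compounds:
Compound 1, `COc1cc(-c2nn(-c3cccc(NC(=O)c4ccc(Cl)c(C(F)(F)F)c4)c3)cc2-c2ccncc2)ccc1Cl`, gives 31800 nM in a functional assay on SK-MEL-5 cells (Homo sapiens) for inhibition, read by sulforhodamine B assay, with a stated time of 48 h; on this read-out lower numbers stand for higher toxicity in this test and higher numbers for lower toxicity in this test.
Compound 2, `O=C(Nc1cccc(-n2cc(-c3ccncc3)c(-c3ccc(Cl)c(O)c3)n2)c1)Nc1cc(C(F)(F)F)cc(C(F)(F)F)c1`, gives 2620 nM.
Compound 3, `COc1cc(-c2nn(-c3cccc(NC(=O)Nc4cccc(C(F)(F)F)c4)c3)cc2-c2ccncc2)ccc1Cl`, gives 2680 nM.

Compound 3 stands second highest of the three numbers. Its nearest neighbour is compound 2, whose value lies within the scatter of that of compound 3, so the two cannot be ordered. Among the measured compounds shown here, its furthest neighbour is compound 1, and the only step between compounds that differ in one place is a 12-fold lower number from compound 1 to compound 3 (1.07 log units; beyond the scatter), which concerns the exchange of an amide for a urea rather than the change now in question.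

Compound 4, `COc1cc(-c2nn(-c3cccc(NC(=O)Nc4cc(C(F)(F)F)cc(C(F)(F)F)c4)c3)cc2-c2ccncc2)ccc1Cl`, differs from compound 3 by trifluoromethyl in place of hydrogen on an aromatic carbon, on a six-membered aromatic ring of carbon only. For the measured compounds named here, no measured step isolates this change. Going by the values given here, the only pointer is compound 2, which carries the same two trifluoromethyl groups on its urea while its other end differs from compound 3, and whose value sits within the scatter of compound 3. On that basis the author expects the step of a 1.1-fold lower number from compound 3 to compound 4 (0.03 log units; within the scatter) to stay within the scatter, in no firm direction. Compound 4 is therefore estimated at 2500 nM, with a range from 1000 nM to 6500 nM.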

Compound 4, concentration lethal to 50% of the cells: 2670 nM
Compound 4: middle estimate off by 1.1-fold (0.03 log units), on the low side; measured number inside the range.
By their numbers in this assay, from the lowest: compounds 2, 4 and 3 (each within the scatter of the next); then compound 1.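

In this assay the exchange of hydrogen for trifluoromethyl on an aromatic carbon can now be read directly, and a 1.0-fold lower number from compound 3 to compound 4 (0.00 log units; within the scatter) shows that this group of 4 heavy atoms, placed meta to a trifluoromethyl group on the six-membered aromatic ring of carbon only, leaves the number where it was. The other end of the molecule gives a matching reading: with methyl in place of hydrogen on an oxygen on an aromatic ring, a 1.0-fold higher number from compound 2 to compound 4 (0.01 log units; within the scatter) separates the hydroxyl and methoxy forms by no more than the scatter when the urea carries two trifluoromethyl groups. No evidence at hand bears on either result.

From the compounds shown here alone, whether this carbon would accept other groups as readily, such as a methyl, a nitrile, an amine or a carboxylic acid, remains open, since trifluoromethyl alone has been read here. Among the compounds shown here, it also remains open whether the hydroxyl and methoxy forms would still match with only one trifluoromethyl group on the urea, or with a longer alkyl ether on that oxygen.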